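Working notes on compounds 1 to 4, compound 4 pending

The compounds below may be only part of what the source reports. "The series", "measured", "known", "first", "only" and "open" are said of these compounds alone.

Compound 1 `O=c1ccn([C@H]2C[Se][C@@H](CO)O2)c(=O)[nH]1` in a functional assay on PBM cells (Homo sapiens) for cytotoxicity (on this read-out higher numbers stand for weaker inhibition and lower numbers for stronger inhibition), gives > 100000 nM, a limit of the assay.
Compound 2 `Cc1cn([C@H]2C[Se][C@@H](CO)O2)c(=O)[nH]c1=O` in this assay gives > 100000 nM, a limit of the assay.
Compound 3 `O=c1ccn([C@@H]2C[Se][C@@H](CO)O2)c(=O)[nH]1` in this assay gives > 100000 nM, a limit of the assay.

Compound 3 thus stands only as a limit, and the two further values shown are limits as well. The step that the two limits leave unreadable from compound 1 to compound 2 has no readable size, and the same holds for a step that the two limits leave unreadable from compound 1 to compound 3; both are unreadable due to the limit of > 100000 nM in this assay, at which 3 of the 3 values shown sit.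

Compound 4 `Cc1cn([C@@H]2C[Se][C@@H](CO)O2)c(=O)[nH]c1=O` is still to be measured in this assay. Its difference from compound 3 is methyl in place of hydrogen on an aromatic carbon. The step from compound 1 to compound 2 is the same kind of change on the other drawn configuration, so it is the one that bears here, together with the fact that compounds 1 and 3 differ only in the configuration as drawn; neither yields a size. No step beyond the scatter is therefore expected, and the most likely outcome is that compound 4 again sits at the limit. The estimate implies a step that the limit leaves unreadable from compound 3 to compound 4, expected to be none beyond the scatter. Compound 4 is estimated at 200000 nM, with a range from 50000 nM to 1000000 nM.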

Compound 4, half-maximal inhibitory concentration: > 100000 nM
Compound 4: only a limit was reported; the forecaster's own chance of this, stated with the estimate: 90%; the middle value lies beyond the limit too.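

In this assay compound 4 gives > 100000 nM, which is a limit of the assay. No new step can be read from compound 3 or compound 2 to compound 4. The compounds shown leave open whether methyl in place of hydrogen on an aromatic carbon, or the drawn configuration, changes this read-out at all.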